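The source may report more compounds than this note shows. Statements on the series, on what has been measured and on what is new or still open speak of the compounds shown alone.

Compound 1, `CC(C)c1n[nH]c2c(NCc3ccc(-c4ccccn4)cc3)nc(SCC(O)CO)nc12`: in a functional assay on HT cells (Homo sapiens) for antiproliferative activity, read by fluorescence, with a stated time of 72 h (on this read-out higher numbers stand for weaker inhibition of growth and lower numbers for stronger inhibition of growth), compound 1 gives 21 nM.
Compound 2, `CC(C)c1n[nH]c2c(NCc3ccc(-c4ccccn4)cc3)nc(SCCCO)nc12`: in this assay compound 2 gives 109 nM.
Compound 3, `CC(C)c1n[nH]c2c(NCc3ccc(-c4ccccn4)cc3)nc(SCCCN)nc12`: in this assay compound 3 gives 120 nM.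

Compound 1 has the lowest number of the three. The step of a 5.2-fold higher number from compound 1 to compound 2 (0.72 log units; beyond the scatter) and the step of a 5.7-fold higher number from compound 1 to compound 3 (0.76 log units; beyond the scatter) both go beyond the scatter, whereas a 1.1-fold higher number from compound 2 to compound 3 (0.04 log units; within the scatter). Compound 4, `CC(=O)NCCSc1nc(NCc2ccc(-c3ccccn3)cc2)c2[nH]nc(C(C)C)c2n1`, differs from compound 1 by acetamidomethyl in place of 1,2-dihydroxyethyl on a saturated chain carbon bound to a sulfur. The two steps that bear on this change, from compound 1 to compound 2 and from compound 1 to compound 3, each replaced part of the 1,2-dihydroxyethyl group and each gave a modest rise. A rise of similar size is therefore expected in this assay for compound 4, a 5.7-fold higher number from compound 1 to compound 4 (0.76 log units; beyond the scatter). Compound 4 is estimated at 120 nM, with a range from 40 nM to 400 nM.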

Compound 4, concentration for 50% growth inhibition: 71 nM
The estimate for compound 4 lay 1.7-fold (0.23 log units) above the measured number, within the range that was stated.
By their numbers in this assay, from the lowest: compound 1; then compounds 4, 2 and 3 (each within the scatter of the next).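

In this assay, acetamidomethyl in place of 1,2-dihydroxyethyl also loses ground from compound 1 (a 3.4-fold higher number from compound 1 to compound 4 (0.53 log units; beyond the scatter)), so a third replacement at this position fails to match it. The new acetamido end does not separate from the amino end (a 1.7-fold lower number from compound 3 to compound 4 (0.23 log units; within the scatter)) or the hydroxy end (a 1.5-fold lower number from compound 2 to compound 4 (0.19 log units; within the scatter)), leaving compound 1 alone apart from the other three. Nothing measured here accounts for this difference. On these data alone, whether a carboxylic acid or a longer chain ending in 1,2-dihydroxyethyl would match compound 1 in this assay remains open.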